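The source may hold more compounds than are shown below. What is called first, only, known or untested is meant among the compounds shown, and "the series" means these compounds.

In a functional assay on HCT-116 cells (Homo sapiens) for cytotoxicity, read by resazurin assay, with a stated time of 72 h (on this read-out lower numbers stand for stronger inhibition and higher numbers for weaker inhibition), compound 1 `COc1cc(OC)c(C(C)=O)c(OC)c1` gives only a limit of the assay, > 20000 nM. Compound 2 `COc1cc(OC)c(C(=O)/C=C/c2ccccc2)c(OC)c1` likewise returns a limit and not a number in this assay, > 20000 nM. Compound 2 therefore stands at the ceiling of everything measured so far: the limit of > 20000 nM in this assay, at which 2 of the 2 values shown sit. Within the data shown here, no ranking within the pair is possible, and no step between two measured compounds exists from which the effect of a change on the shared core could be read.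

Compound 3 `C=CCOc1ccccc1Cc1c(OC)cc(OC)c(C(=O)/C=C/c2ccccc2)c1OC` is the next compound to be measured in this assay. It differs from compound 2 by 2-(allyloxy)benzyl in place of hydrogen on an aromatic carbon. With both measured values sitting at the same limit, the measured set gives no direction for this change, and the expectation rests on the structural change alone. The step expected in this assay is an at least 1.6-fold lower number from compound 2 to compound 3 (0.22 log units; that floor lies within the scatter), a move toward stronger inhibition of uncertain size, and a result that again sits at the limit cannot be excluded. Compound 3 is estimated at 12000 nM in this assay. The expected range for compound 3 runs from 2000 nM to 40000 nM.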

Compound 3, half-maximal inhibitory concentration: > 20000 nM
Compound 3 was reported as a limit (the forecaster's own chance of this, stated with the estimate: 55%); middle value at least 1.6-fold (0.22 log units) from the limit.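

In this assay compound 3 returns only a limit of the assay, > 20000 nM. Among these compounds, compound 2 also sits at a limit, so no step between compound 2 and compound 3 can be read. All values shown stand at one ceiling: the limit of > 20000 nM in this assay, at which 3 of the 3 values shown sit.

The compounds shown leave open whether any change on the shared core gives a measurable value in this assay.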